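The compounds below may be only part of what the source reports. "The series", "measured", "known", "first", "only" and "open" are said of these compounds alone.

Compound 3 `COc1cc2c(cc1N1C[C@@H](C)N[C@@H](C)C1)N(S(=O)(=O)c1ccc(-c3ccccn3)s1)CC2` gives the lowest number of the three compounds measured in a functional assay for agonist activity at growth hormone secretagogue receptor type 1 (Homo sapiens), read by FLIPR (a lower number here means that less compound is needed, a higher number that more compound is needed for the effect), at 0.159 nM. Compound 1 `COc1cc2c(cc1N1C[C@@H](C)N[C@@H](C)C1)N(S(=O)(=O)c1ccc3ccccc3c1)CC2` gives 0.501 nM, and compound 2 `COc1cc2c(cc1N1C[C@@H](C)N[C@@H](C)C1)N(S(=O)(=O)Cc1cccc(I)c1)CC2` gives 31.6 nM. The measured steps all concern the group on the sulfonyl sulfur: a 3.2-fold lower number from compound 1 to compound 3 (0.50 log units; beyond the scatter), a 63-fold higher number from compound 1 to compound 2 (1.80 log units; beyond the scatter) and a 200-fold lower number from compound 2 to compound 3 (2.30 log units; beyond the scatter).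

Compound 4 `COc1cc2c(cc1N1C[C@@H](C)NC(C)(C)C1)N(S(=O)(=O)c1ccc(-c3ccccn3)s1)CC2` differs from compound 3 elsewhere, with a group of 9 heavy atoms (7 carbon, 2 nitrogen; one six-membered non-aromatic ring with 2 hetero atoms) in place of a group of 8 heavy atoms (6 carbon, 2 nitrogen; one six-membered non-aromatic ring with 2 hetero atoms), on an aromatic carbon. Within the data shown here, none of the measured steps touches this part of the molecule, so no measured step bears directly on the change; all that can be said is that the three measured compounds share the 3,5-dimethylpiperazin-1-yl group and all give low numbers in this assay. With no evidence either way, the step from compound 3 to compound 4 is expected to be small and most likely towards a somewhat higher number, a 2.2-fold higher number from compound 3 to compound 4 (0.34 log units; beyond the scatter). Compound 4 is therefore estimated at 0.35 nM in this assay, within a range of 0.08 nM to 1.6 nM.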

Compound 4, half-maximal effective concentration: 10 nM
For compound 4 the middle estimate is 29-fold (1.46 log units) below the measured one; the whole stated range lies below it.
By their numbers in this assay, from the lowest: compound 3; then compound 1; then compound 4; then compound 2.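

In this assay, putting the group of 9 heavy atoms, with 1 defined stereocentre, in place of the 3,5-dimethylpiperazin-1-yl group, with 2, gives a 63-fold higher number from compound 3 to compound 4 (1.80 log units; beyond the scatter). This position, ortho to a methoxy group, therefore responds strongly to a change that leaves the ring size, the net charge and the counts of hydrogen-bond donors and acceptors as they were. The earlier steps shown here all lay on the sulfonyl sulfur, and this change elsewhere in the molecule moves the number as far as a 63-fold higher number from compound 1 to compound 2 (1.80 log units; beyond the scatter). Nothing shown here explains the size of this step.

The compounds shown leave open whether the same change would weigh as heavily with the naphthalen-2-yl or 3-iodobenzyl group on the sulfonyl sulfur. They also leave open how an unsubstituted piperazin-1-yl or a morpholin-4-yl group would read at this position.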